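A Smaller Group on the Aromatic Nitrogen

The source may report more compounds than this note shows. Statements on the series, on what has been measured and on what is new or still open speak of the compounds shown alone.

Compound 1, `COC[C@@H](C1CC1)n1cc(Cl)nc(Nc2cc(C)c(OC)nc2C)c1=O`, gives 40% in an ADME assay on microsomes from liver (Homo sapiens) for metabolic stability, read by HPLC, with a stated time of 10 min, tested at 3 uM; a higher number here means that more of the compound is left, a lower number that less of the compound is left.
Compound 2, `CC[C@H](C1CC1)n1cc(Cl)nc(Nc2cc(C)c(OC)nc2C)c1=O`, gives 51% in this assay.

Of the two compounds measured in this assay, compound 2 stands highest, with compound 1 nearest to it, a number 11 percentage points higher from compound 1 to compound 2 (beyond the scatter). The unmeasured compound 3, `COC[C@@H](C)n1cc(Cl)nc(Nc2cc(C)c(OC)nc2C)c1=O`, carries 1-(methoxymethyl)ethyl in place of 1-cyclopropylpropyl on an aromatic nitrogen. Going by the values given here, only one measured step bears on this change, a number 11 percentage points higher from compound 1 to compound 2 (beyond the scatter), in which 1-cyclopropylpropyl replaced 1-cyclopropyl-2-methoxyethyl on the aromatic nitrogen. Among the compounds with values here, the move to compound 3 runs that exchange backwards, bringing the methoxy-bearing chain back, while at the same time trading the three-membered ring for a plain chain, a part of the change that no measured pair covers. Taking the one measured step as the guide and leaving the rest open, a modest fall is expected, a number 9 percentage points lower from compound 2 to compound 3 (within the scatter), with wide uncertainty. Compound 3 is therefore estimated at 42%, in a range from 25% to 60%.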

Compound 3, percent of the compound remaining: 39%
Compound 3: the middle estimate sits 3 percentage points above what was measured; the measured number falls inside the stated range.
By their numbers in this assay, from the lowest: compounds 3 and 1 (each within the scatter of the next); then compound 2.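

The third compound separates the two parts of the change: with the methoxy-bearing chain in place, methyl in place of cyclopropyl on the chain carbon bound to the aromatic nitrogen gives no readable shift in this assay, a number 1 percentage points lower from compound 1 to compound 3 (within the scatter). The full exchange of 1-cyclopropylpropyl for 1-(methoxymethyl)ethyl does register, a number 12 percentage points lower from compound 2 to compound 3 (beyond the scatter), so among these three compounds the one without the methoxy group stands apart, while the cyclopropyl ring can be lost in this pair without a readable change. Nothing measured here explains these numbers.

On these data alone, it remains open whether methyl in place of cyclopropyl would also pass unread on the chain without the methoxy group. How a hydroxyl in place of the methoxy, or a longer chain on the aromatic nitrogen, would fare is also unknown.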